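Trimethoxyphenyl triazole series: cytotoxicity notes before compound 4

The source may hold more compounds than are shown below. What is called first, only, known or untested is meant among the compounds shown, and "the series" means these compounds.

Compound 1 `Cc1nnc(SCC(=O)c2ccc(Cl)cc2)n1N1C(=O)c2ccccc2C1=O` carries a methyl on the shared core. In a functional assay on MKN-45 cells (Homo sapiens) for cytotoxicity, read by MTT assay, with a stated time of 48 h (on this read-out higher numbers stand for weaker inhibition and lower numbers for stronger inhibition), compound 1 gives > 200000 nM, which is a limit of the assay and not a number. Compound 2 `C=CCSc1nnc(-c2cc(OC)c(OC)c(OC)c2)n1N1C(=O)c2ccccc2C1=O` gives > 200000 nM in this assay, again a limit. Compound 3 `COc1cc(-c2nnc(SCc3ccccc3Cl)n2N2C(=O)c3ccccc3C2=O)cc(OC)c1OC` gives > 200000 nM in this assay, also a limit. The change a step that the two limits leave unreadable from compound 2 to compound 3 cannot be sized, as both ends are limits. Compound 3 therefore stands only at a limit; the other two values shown are limits as well, and all three sit at the limit of > 200000 nM in this assay, at which 3 of the 3 values shown sit.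

Compound 4 `COc1cc(-c2nnc(SCC(=O)c3ccc(Cl)cc3)n2N2C(=O)c3ccccc3C2=O)cc(OC)c1OC` differs from compound 3 by (4-chlorophenyl)carbonyl in place of 2-chlorophenyl on a saturated chain carbon bound to a sulfur. Among the measured compounds shown here, no step measured so far bears on it in a readable way: the only step within the set is unreadable, and compound 1, which carries the same (((4-chlorophenyl)carbonyl)methyl)sulfanyl group on a different core, shows only a limit in this assay. Nothing in the numbers points to a step beyond the scatter in either direction, and a further limit is the most likely outcome. For compound 4 in this assay the expected value is 200000 nM, with a range from 100000 nM to 400000 nM. The estimated step of a number no higher from compound 3 to compound 4 (the limit leaves the size open) is expected to be unreadable.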

Compound 4, half-maximal inhibitory concentration: 26600 nM
Compound 4: middle estimate off by 7.5-fold (0.88 log units), on the high side; measured number below the stated range.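

Placing (4-chlorophenyl)carbonyl in place of 2-chlorophenyl on a saturated chain carbon bound to a sulfur produces the first readable activity in this assay, with an at least 7.5-fold lower number from compound 3 to compound 4 (0.87 log units; beyond the scatter), and the same place read against vinyl gives an at least 7.5-fold lower number from compound 2 to compound 4 (0.87 log units; beyond the scatter). The side chain alone does not account for this, since 3,4,5-trimethoxyphenyl in place of methyl on an aromatic carbon, with that chain held constant, gives an at least 7.5-fold lower number from compound 1 to compound 4 (0.87 log units; beyond the scatter); among these four compounds, a number appears only where the trimethoxyphenyl group and the (((4-chlorophenyl)carbonyl)methyl)sulfanyl group stand together. Compound 4 is the only one of the four to leave the assay limit, and the other three remain at it: the limit of > 200000 nM in this assay, at which 3 of the 4 values shown sit.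

On these data alone, the step from compound 2 to compound 3 cannot be read, and the change to compound 4 alters both the carbonyl and the chlorophenyl group at once, so the share of each in the step stays open. Also open, as far as these compounds go, is how the series responds at the same place to a (4-fluorophenyl)carbonyl group, a plain phenylcarbonyl group or a longer chain carrying an amine.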